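Hydroxy added to the isopropyl arm of compound 3

The source may report more compounds than this note shows. Statements on the series, on what has been measured and on what is new or still open speak of the compounds shown alone.

For the measured compounds named here, compound 3 `CC(C)c1ccc(C(=O)N2CCC(n3cncc3-c3ccc(OS(=O)(=O)c4cccc5cnccc45)cc3)CC2)cc1` gives 55 nM in an assay on HEK293 cells for antagonist activity at P2X purinoceptor 7 (Homo sapiens), read by fluorescence, with a stated time of 2 h (on this read-out higher numbers stand for weaker inhibition and lower numbers for stronger inhibition), the highest number of the three measured members. Compound 1 `O=C(c1ccc([N+](=O)[O-])cc1)N1CCC(n2cncc2-c2ccc(OS(=O)(=O)c3cccc4cnccc34)cc2)CC1` gives 1.49 nM and compound 2 `CN(C)c1ccc(C(=O)N2CCC(n3cncc3-c3ccc(OS(=O)(=O)c4cccc5cnccc45)cc3)CC2)cc1` gives 0.11 nM. The measured steps are a 37-fold higher number from compound 1 to compound 3 (1.57 log units; beyond the scatter), a 500-fold higher number from compound 2 to compound 3 (2.70 log units; beyond the scatter) and a 14-fold lower number from compound 1 to compound 2 (1.13 log units; beyond the scatter); all three concern the group on the aromatic carbon, and none touches the saturated chain carbon of the isopropyl group.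

Compound 4 `CC(C)(O)c1ccc(C(=O)N2CCC(n3cncc3-c3ccc(OS(=O)(=O)c4cccc5cnccc45)cc3)CC2)cc1` differs from compound 3 by hydroxy in place of hydrogen on a saturated chain carbon bound to an aromatic carbon and two saturated chain carbons. Going by the values given here, no measured pair shows this change, so the series offers no direct precedent; it only shows that the group at this end of the molecule moves the numbers strongly, with the large steps from compound 1 to compound 3 and from compound 2 to compound 3 marking compound 3 as the weakest of the three. A hydroxy on the chain carbon is a different change from exchanging the aromatic substituent, and its direction is not fixed by the data.

For compound 4 a moderate step toward a lower number, a 2.8-fold lower number from compound 3 to compound 4 (0.44 log units; beyond the scatter), is estimated, with wide uncertainty. Compound 4 is expected to give about 20 nM in this assay, within 4 nM to 100 nM.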

Compound 4, half-maximal inhibitory concentration: 109 nM
Compound 4: the middle estimate sits 5.5-fold (0.74 log units) below what was measured; measured number above the stated range.
By their numbers in this assay, from the lowest: compound 2; then compound 1; then compounds 3 and 4 (each within the scatter of the next).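

In this assay, for the compounds shown here, a 2.0-fold higher number from compound 3 to compound 4 (0.30 log units; within the scatter), so this is the first change at this end of the molecule that the assay does not resolve: hydroxy in place of hydrogen on the saturated chain carbon leaves compound 4 indistinguishable from compound 3, whereas every earlier step here lay beyond the scatter. The 1-hydroxy-1-methylethyl group stays as far from the two stronger members as isopropyl does, with a 990-fold higher number from compound 2 to compound 4 (3.00 log units; beyond the scatter) and a 73-fold higher number from compound 1 to compound 4 (1.86 log units; beyond the scatter), so among these four compounds the large differences follow the exchange of the whole group on the aromatic carbon and are not altered by this added hydroxy. No measurement is available that could explain these numbers or the gaps between them.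

Still open, on these data alone, is whether the saturated chain carbon tolerates other replacements for hydrogen in the same way, such as a methoxy, an amine or a fluorine atom, or whether the hydroxy result is particular to that group. The compounds shown also do not settle how a carboxylic acid, a methoxy or a longer chain on the aromatic carbon would compare with dimethylamino and nitro.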